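The source may report more compounds than this note shows. Statements on the series, on what has been measured and on what is new or still open speak of the compounds shown alone.

For the measured compounds named here, compound 2 `Cc1cc(-n2ccc3cccnc32)cn2c(CSCCc3ccccc3)cnc12` is the only compound here with a plain number: in an ADME assay on HEL cells (Homo sapiens) for cytotoxicity, with a stated time of 3 days (on this read-out lower numbers stand for higher toxicity in this test and higher numbers for lower toxicity in this test), compound 2 gives 20 ug/mL. Compound 1 `Cc1cc(-c2ccco2)cn2c(CSCCc3ccccc3)cnc12` is reported in this assay only as a limit, > 4 ug/mL. The step that the limit leaves unreadable from compound 1 to compound 2 is therefore unreadable. Compound 3 `Cc1cc(Sc2ccc(Cl)cc2)cn2c(CSCCc3ccccc3)cnc12` differs from compound 2 in one place: a group of 8 heavy atoms (6 carbon, 1 sulfur, 1 chlorine; one six-membered aromatic ring of carbon only) in place of a group of 9 heavy atoms (7 carbon, 2 nitrogen; one five-membered aromatic ring with 1 hetero atom, one six-membered aromatic ring with 1 hetero atom), on an aromatic carbon. Going by the values given here, no measured step in this set speaks to such a change, so for compound 3 a step in this assay of no change at the digits printed from compound 2 to compound 3 (within the scatter) is expected, meaning no shift beyond the usual scatter. Compound 3 is estimated at 20 ug/mL, with a range from 7 ug/mL to 50 ug/mL.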

Compound 3, minimum cytotoxic concentration: 20 ug/mL
Beside the measured number, compound 3's estimate shows no gap at the digits printed; low and high end bracket the measured number.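

In this assay, putting (4-chlorophenyl)sulfanyl on this aromatic carbon, two atoms from the ring nitrogen, in place of the two-ring group gives no change at the digits printed from compound 2 to compound 3 (within the scatter). At this position, then, two groups with different rings and different hetero atoms cannot be told apart on this read-out. The steps from compound 1 cannot be read, because its value is a limit: the limit of > 4 ug/mL in this assay, at which 1 of the 3 values shown sits.

As far as these compounds go, how furan-2-yl truly compares with the other two groups stays open. So does whether an amine or a carboxylic acid at this position would shift the read-out.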